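Compound 3: a dichlorophenyl in place of a bromophenyl

The source may report more compounds than this note shows. Statements on the series, on what has been measured and on what is new or still open speak of the compounds shown alone.

- compound 1 `COC(=O)C1=C(C)N=C(C)/C(=C(\O)OC)C1c1ccccc1OC`: 57.5 nM
- compound 2 `COC(=O)C1=C(C)N=C(C)/C(=C(\O)OC)C1c1ccccc1Br`: 7.59 nM

For the measured compounds named here, in a functional assay (muscle tissue) with Cavia porcellus as the target (on this read-out lower numbers stand for an effect already at smaller amounts and higher numbers for an effect only at larger amounts of compound), compound 2 gives 7.59 nM, the lower of the two numbers so far, and its gap to compound 1 lies beyond the scatter. The next compound, compound 3 `COC(=O)C1=C(C)N=C(C)/C(=C(\O)OC)C1c1c(Cl)cccc1Cl`, keeps the shared core and changes one group: 2,6-dichlorophenyl in place of 2-bromophenyl on a saturated ring carbon. Here 2,6-dichlorophenyl stands in place of 2-bromophenyl on a saturated ring carbon.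

Going by the values given here, only one measured step bears on this change, and only indirectly: a 7.6-fold lower number from compound 1 to compound 2 (0.88 log units; beyond the scatter). This modest step shows that this assay can separate compounds that differ on the aromatic group. However, no measured compound carries chlorine or a second substituent on that group, so the step gives no direction for compound 3. The best expectation is therefore no step beyond the scatter, with real room for a move of similar size either way. The expected change is a 1.3-fold higher number from compound 2 to compound 3 (0.12 log units; within the scatter). Compound 3 is estimated at 10 nM, with an expected range from 2.5 nM to 40 nM.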

Compound 3, half-maximal effective concentration: 1.91 nM
Compound 3: middle estimate off by 5.2-fold (0.72 log units), on the high side, and the stated range ends above it.
By their numbers in this assay, from the lowest: compound 3; then compound 2; then compound 1.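

In this assay, the move to 2,6-dichlorophenyl gives a 4.0-fold lower number from compound 2 to compound 3 (0.60 log units; beyond the scatter), so the number at this saturated ring carbon can fall further when the aromatic group carries two chlorines rather than one bromine. For the compounds shown here, the earlier pair showed only that the group at this place matters, and had no chlorine and no second substituent on the aromatic ring. Measured against the methoxy compound, the same change gives a 30-fold lower number from compound 1 to compound 3 (1.48 log units; beyond the scatter), a large span for three compounds that differ only in this one group, and nothing available here gives a reason for the drop.

Bromine leaves and two chlorines enter in a single move, so the compounds shown cannot separate the effect of swapping the halogen from the effect of adding a second substituent, and a compound with a single chlorine or with two bromines would be needed to pull these apart. From the compounds shown here alone, how this assay would read a phenyl carrying an amine, a carboxylic acid or a nitro group at this place also stays open.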